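A few compounds are considered here, and "the series" means these few. Any claim that something is new, unique, unknown or untested is made for them only; others in the source may bear on it.

Three compounds share one core and differ only in the aryl group carried on the ring nitrogen. Compound 1 is `CNC(=O)c1cc(Oc2ccc3nc(Nc4ccccc4Br)ncc3c2)ccn1`, compound 2 is `CCc1ccccc1Nc1ncc2cc(Oc3ccnc(C(=O)NC)c3)ccc2n1` and compound 3 is `CNC(=O)c1cc(Oc2ccc3nc(Nc4cccc(Cl)c4)ncc3c2)ccn1`. In a physicochemical assay for solubility, at pH 7 (on this read-out higher numbers stand for higher solubility and lower numbers for lower solubility), compound 1 gives only a limit of the assay, < 1000 nM. Compound 2 likewise gives in this assay a limit, < 1000 nM. Compound 3 too gives in this assay no number but a limit, < 1000 nM. The steps between them, a step that the two limits leave unreadable from compound 1 to compound 2, a step that the two limits leave unreadable from compound 1 to compound 3 and a step that the two limits leave unreadable from compound 2 to compound 3, cannot be sized, because of the limit of < 1000 nM in this assay, at which 3 of the 3 values shown sit. Compound 3 therefore stands at the limit, and nothing in the set places it above or below its two partners.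

Compound 4 is `CNC(=O)c1cc(Oc2ccc3nc(Nc4cccc(C(F)(F)F)c4)ncc3c2)ccn1`. It differs from compound 3 by trifluoromethyl in place of chloro on an aromatic carbon. Among the compounds with values here, since none of the three measured steps is readable, none of them gives a size or a direction for the change to expect in this assay; the only thing the measured compounds show is that every one of them sits at the same limit. Compound 4 is accordingly expected to remain there as well, with an estimate of 500 nM and a range from 100 nM to 1500 nM. The expected step is a step that the limit leaves unreadable from compound 3 to compound 4, which is to say no readable movement.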

Compound 4, solubility: < 1000 nM
Compound 4 gave a limit, no number; the forecaster's own chance of this, stated with the estimate: 80%; the middle value lies beyond the limit too.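

Compound 4 joins compound 1, compound 2 and compound 3 at one limit in this assay, so none of the steps from compound 4 to the other three can be read: the limit of < 1000 nM in this assay, at which 4 of the 4 values shown sit.

The compounds shown leave open how far apart these four lie in this assay, and whether changing the aryl group on the nitrogen moves the read-out at all.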